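Isopropyl to Ethyl: One Carbon Less for Compound 4

This account rests on a few compounds, and the source may have more. Where it says the series, first, only, none or still open, it means among the compounds named here.

compound 1, `CC1CCC(C(C)C)C(OC(=O)C#CC(O/C=C/C(=O)OC2CC(C)CCC2C(C)C)C(C)C)C1`: > 100000 nM
compound 2, `COC(=O)C#CC(O/C=C/C(=O)OC)C(C)C`: 450 nM
compound 3, `COC(=O)/C=C/OC(C#CC(=O)O)C(C)(C)C`: > 100000 nM

Three compounds have been run in a functional assay on HBL-100 cells (Homo sapiens) for antiproliferative activity, read by sulforhodamine B assay, with a stated time of 48 h; a lower number here means a stronger inhibitor of growth, a higher number a weaker inhibitor of growth. Compound 1 gives > 100000 nM, which is a limit of the assay and not a number. Compound 3 gives > 100000 nM, again a limit. Among the compounds with values here, compound 2 gives 450 nM, and this is the only true number in the set. Within the data shown here, the other two entries are the limit of > 100000 nM in this assay, at which 2 of the 3 values shown sit, so compound 2 stands alone as the one compound with a measurable growth-inhibitory concentration.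

Compound 4, `CCC(C#CC(=O)OC)O/C=C/C(=O)OC`, has not yet been measured in this assay. It differs from compound 2 in one place: hydrogen in place of methyl on a saturated chain carbon bound to two saturated chain carbons. Among the measured compounds shown here, no step between two measured compounds is available, so the size of such a change cannot be read from the data in hand. A change of one carbon on a saturated chain is small, and the step is expected to be a 1.6-fold higher number from compound 2 to compound 4 (0.19 log units; within the scatter), lying within the usual scatter or only slightly beyond it toward weaker inhibition. Compound 4 is therefore estimated at 700 nM, with a range from 200 nM to 3000 nM.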

Compound 4, concentration for 50% growth inhibition: 320 nM
For compound 4 the middle estimate is 2.2-fold (0.34 log units) above the measured one, and the stated range covers the measured number.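

Within the data shown here, the first step that can be read, taken in this assay, is a 1.4-fold lower number from compound 2 to compound 4 (0.15 log units; within the scatter), for hydrogen in place of methyl on a saturated chain carbon bound to two saturated chain carbons. At this place, isopropyl and ethyl cannot be told apart in this assay, so the carbon that leaves is not needed for the growth inhibition seen with compound 2, and compound 4 still gives a true number and not a limit. Nothing in the data shown gives a reason for this result or bears on it.

What the compounds shown leave open is how much larger a change this position can take, for instance a longer chain such as n-butyl, a phenyl ring or an amine in place of the ethyl of compound 4. Compound 1 and compound 3 each differ from compound 2 in more than one place and are recorded only as limits of the assay, so steps to them cannot be read and the part played by each of the other groups remains unresolved.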